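This account rests on a few compounds, and the source may have more. Where it says the series, first, only, none or still open, it means among the compounds named here.

Measured so far, in a physicochemical assay for acid dissociation:
Compound 1, `CC(=O)OCCS(=O)(=O)c1ccc(S(N)(=O)=O)s1`, gives 8.65.
Compound 2, `NS(=O)(=O)c1ccc(S(=O)(=O)CCCO)s1`, gives 8.32.
Compound 3, `CC(=O)OCCCCc1ccc(S(N)(=O)=O)cc1`, gives 10.5.

Compound 1 and compound 2 share a core and differ in one place: hydroxymethyl in place of acetoxy on a saturated chain carbon, two bonds along the chain from a sulfonyl sulfur. That change gave a number 0.33 log units lower from compound 1 to compound 2 (beyond the scatter). Compound 3 stands highest of the three, and its gaps to compound 1 and to compound 2 both lie beyond the scatter. How the core of compound 3 differs from the core of compound 1 is not broken down here.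

Compound 4, `NS(=O)(=O)c1ccc(CCCCCO)cc1`, has not yet been measured in this assay. It differs from compound 3 by hydroxymethyl in place of acetoxy on a saturated chain carbon, four bonds along the chain from an aromatic carbon. For the measured compounds named here, this is the same kind of change as the one from compound 1 to compound 2, though the place is not the same: there the group sat two bonds along the chain from a sulfonyl sulfur, here it sits four bonds along the chain from an aromatic carbon. Judged against a number 0.33 log units lower from compound 1 to compound 2 (beyond the scatter), the step expected here is a number 0.20 log units lower from compound 3 to compound 4 (within the scatter). With the group further out along the chain, a step no larger than the earlier one is expected. Compound 4 is therefore expected to give about 10.3, most likely between 9.9 and 10.7.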

Compound 4, acid dissociation constant: 10.3
For compound 4 middle estimate and measured number coincide at the digits printed; measured number inside the range.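

In this assay, hydroxymethyl in place of acetoxy gave a number 0.20 log units lower from compound 3 to compound 4 (within the scatter) on this core, against a number 0.33 log units lower from compound 1 to compound 2 (beyond the scatter) on the other core. The new step therefore cannot be told apart from the ordinary spread of repeated measurements, and only the earlier step stands clear of that spread. This does not show that the change has a fixed size from core to core: the two pairs also differ in place, with the group two bonds along the chain from a sulfonyl sulfur in one and four bonds along the chain from an aromatic carbon in the other, and no information is available here to explain either result.

The compounds shown leave open whether an amine or a carboxylic acid in place of acetoxy would give a step beyond the scatter on either core. They also leave open what a longer chain would do, and what the same change would do at the same place on both cores, where core and place could be judged separately.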